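Moving a Fluorine on the Pendant Aryl Ring

The compounds below may be only part of what the source reports. "The series", "measured", "known", "first", "only" and "open" are said of these compounds alone.

Compound 1 `CCc1nc(Cl)c2n1CCN([C@@H](C(=O)NC)c1ccccc1)[C@H]2CCc1ccc(C(F)(F)F)cc1F`: 12 nM
Compound 2 `CNC(=O)[C@@H](c1ccccc1)N1CCn2c(C3CC3)nc(Cl)c2[C@@H]1CCc1ccc(C(F)(F)F)c(F)c1`: 10 nM

Both compounds were run in a functional assay on CHO cells for antagonist activity at Orexin receptor type 2 (Homo sapiens), read by FLIPR and calcium flux; on this read-out higher numbers stand for weaker inhibition and lower numbers for stronger inhibition. In this assay compound 2 gives 10 nM, the lower of the two numbers, while compound 1 gives 12 nM; the gap between them lies within the scatter of repeated measurements, so no order can be read from it.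

Compound 3 `CNC(=O)[C@@H](c1ccccc1)N1CCn2c(C3CC3)nc(Cl)c2[C@@H]1CCc1ccc(C(F)(F)F)cc1F` has not yet been measured. It differs from compound 2 in one place: 2-fluoro-4-(trifluoromethyl)phenyl in place of 3-fluoro-4-(trifluoromethyl)phenyl on a saturated chain carbon, two bonds along the chain from a saturated ring carbon. Going by the values given here, compound 1 carries the same 2-fluoro-4-(trifluoromethyl)phenyl group as compound 3, but on a core that differs from that of compound 2 in another position, so no direct step for this single change is available from the measured pair.

Because compound 1 gives 12 nM in this assay while differing from compound 2 in this fluorine position and in the core, the author expects the step of a 1.2-fold higher number from compound 2 to compound 3 (0.08 log units; within the scatter) to be small, in either direction, and not beyond the scatter. Compound 3 is therefore estimated at 12 nM, with a range from 5 nM to 30 nM.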

Compound 3, half-maximal inhibitory concentration: 26 nM
The estimate for compound 3 lay 2.2-fold (0.34 log units) below the measured number, within the range that was stated.
By their numbers in this assay, from the lowest: compounds 2 and 1 (each within the scatter of the next); then compound 3.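

With cyclopropyl held on the aromatic carbon, 2-fluoro-4-(trifluoromethyl)phenyl in place of 3-fluoro-4-(trifluoromethyl)phenyl on a saturated chain carbon, two bonds along the chain from a saturated ring carbon, gives a 2.6-fold higher number from compound 2 to compound 3 (0.41 log units; beyond the scatter) in this assay, so this position does respond to where the fluorine stands on the ring, though only modestly. With 2-fluoro-4-(trifluoromethyl)phenyl held instead, cyclopropyl in place of ethyl on an aromatic carbon gives a 2.2-fold higher number from compound 1 to compound 3 (0.34 log units; beyond the scatter) in this assay, which shows that this second position also responds, again by a modest step. Nothing in the data bears on why either step arises.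

Going by these compounds, what the same fluorine move does with ethyl on the aromatic carbon remains open, so it cannot yet be said whether the two changes act independently of each other. Also open, on these data alone, are the effects of a methoxy group or a nitrile in place of the fluorine, and of a longer chain or an amine in place of cyclopropyl on the aromatic carbon.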